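Hydroxycyclobutyl for morpholinylethyl: expected clearance in hepatocytes

This account rests on a few compounds, and the source may have more. Where it says the series, first, only, none or still open, it means among the compounds named here.

Compound 1 `CNC(=O)c1cc(C(=O)NCC[C@@H]2CNCCO2)cc2c1O[C@H](CF)[C@H]2c1ccccc1`: 1.28 mL/min
Compound 2 `CNC(=O)c1cc(C(=O)NC2CC2)cc2c1O[C@H](CO)[C@H]2c1ccccc1`: < 0.8 mL/min

For the measured compounds named here, in an ADME assay on cells (Hepatocyte, Rattus norvegicus, strain Wistar Han) for pharmacokinetics, read by LC-MS, tested at 0.5 uM (a higher number here means faster removal of the compound, a lower number slower removal), compound 1 gives 1.28 mL/min, the only number in the set. Compound 2 gives < 0.8 mL/min, which is a limit of this assay rather than a number; it is the limit of < 0.8 mL/min in this assay, at which 1 of the 2 values shown sits. Compound 3 `CNC(=O)c1cc(C(=O)N[C@H]2C[C@H](O)C2)cc2c1O[C@H](CF)[C@H]2c1ccccc1` differs from compound 1 by 3-hydroxycyclobutyl in place of 2-(morpholin-2-yl)ethyl on an amide-type nitrogen. No step between measured compounds is shown, so the size of the change is open; a modest move toward slower removal, within or just beyond the scatter, is expected: a 1.4-fold lower number from compound 1 to compound 3 (0.15 log units; within the scatter). Compound 3 is estimated at 0.9 mL/min, likely between 0.5 mL/min and 1.8 mL/min.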

Compound 3, intrinsic clearance in a liver preparation (reported as CLH), per the amount of preparation that the assay uses: 1.84 mL/min
Compound 3: middle estimate off by 2.0-fold (0.31 log units), on the low side; the measured number lies above the stated range.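

Placing 3-hydroxycyclobutyl where 2-(morpholin-2-yl)ethyl stood on the amide-type nitrogen gives, in this assay, a 1.4-fold higher number from compound 1 to compound 3 (0.16 log units; within the scatter). The morpholine ring can thus leave this nitrogen while compound 1 and compound 3 still read alike. Nothing shown accounts for this step. As far as these compounds go, whether the other stereoisomer of 3-hydroxycyclobutyl would read the same remains open. So does the outcome with a carboxylic acid, an open-chain amine or a longer chain on this nitrogen.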